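The compounds below may be only part of what the source reports. "The series", "measured", "known", "first", "only" and "open" are said of these compounds alone.

Compound 1 `COc1ccc(C(=O)/C=C/c2cccnc2)cc1` and compound 2 `COc1cccc(C(=O)/C=C/c2cccnc2)c1` share the same core and differ only in the position of the methoxy group. In an ADME assay on microsomes for inhibition of cytochrome P450 1A1 (Homo sapiens), read by fluorescence, with a stated time of 10 min (on this read-out higher numbers stand for weaker inhibition and lower numbers for stronger inhibition), compound 1 gives 3600 nM, and compound 2 gives 3500 nM, which stands lowest of the two numbers yet within the scatter of the value for compound 1. Compound 3 `COc1ccc(C(=O)/C=C/c2cccnc2)cc1OC` has not yet been tested in this assay; it carries methoxy in place of hydrogen on an aromatic carbon. Within the data shown here, no measured pair here shows what such a change does, so the step of a 1.2-fold lower number from compound 2 to compound 3 (0.07 log units; within the scatter) is expected to be small, with no clear direction beyond the scatter. Compound 3 is therefore estimated at 3000 nM, with a range from 1000 nM to 9000 nM.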

Compound 3, half-maximal inhibitory concentration: 3100 nM
The estimate for compound 3 lay 1.0-fold (0.01 log units) below the measured number, and the stated range covers the measured number.
By their numbers in this assay, from the lowest: compounds 3, 2 and 1 (each within the scatter of the next).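

In this assay, methoxy in place of hydrogen on an aromatic carbon, ortho to a methoxy group and para to a large group, gives a 1.1-fold lower number from compound 2 to compound 3 (0.05 log units; within the scatter) and a 1.2-fold lower number from compound 1 to compound 3 (0.06 log units; within the scatter). This position therefore takes a second methoxy group with no step beyond the scatter, which the two compounds with a single methoxy group could not show. Nothing available offers an explanation for this result. On these data alone, what an amine, a carboxylic acid or a longer chain would do at this position stays open.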